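Swapping chloro for fluoro in a series at the limit

The source may hold more compounds than are shown below. What is called first, only, known or untested is meant among the compounds shown, and "the series" means these compounds.

Compound 3 `Oc1ccc(Cl)cc1/C=N/c1ccc(OCc2ccccc2)cc1` gives in a functional assay, with a stated time of 30 min (a higher number here means a weaker inhibitor, a lower number a stronger inhibitor), only a limit, > 200000 nM. Compound 1 `Cc1ccc(/C=N/c2ccc(OCc3ccccc3)cc2)c(O)c1` likewise shows a limit in this assay, > 200000 nM. Compound 2 `Oc1ccccc1/C=N/c1ccc(OCc2ccccc2)cc1` also stays at a limit, > 200000 nM. All three therefore sit at the limit of > 200000 nM in this assay, at which 3 of the 3 values shown sit, and the steps a step that the two limits leave unreadable from compound 1 to compound 2, a step that the two limits leave unreadable from compound 1 to compound 3 and a step that the two limits leave unreadable from compound 2 to compound 3 cannot be read. Compound 4 `Oc1ccc(F)cc1/C=N/c1ccc(OCc2ccccc2)cc1` differs from compound 3 by fluoro in place of chloro on an aromatic carbon. None of the measured steps has a readable size, and nothing among these compounds suggests that this change would bring compound 4 into the measurable range, so the expectation is that compound 4 again rests at the limit. Compound 4 is thus expected at 300000 nM, between 100000 nM and 2000000 nM, an estimated step that the limit leaves unreadable from compound 3 to compound 4.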

Compound 4, half-maximal inhibitory concentration: > 200000 nM
Compound 4 gave a limit, no number; the forecaster's own chance of this, stated with the estimate: 90%; the middle value is on the limit's open side.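

In this assay compound 4 gives > 200000 nM, which is a limit and not a number. For the compounds shown here, no step to it from compound 1, compound 2 or compound 3 can be read. The compounds shown leave open which change, if any, would bring this series into the measurable range.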